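From benzyl to methylsulfonyl on a shared core

The source may hold more compounds than are shown below. What is called first, only, known or untested is meant among the compounds shown, and "the series" means these compounds.

In a functional assay on HCT-8 cells (Homo sapiens) for cytotoxicity (a higher number here means that more compound is needed for the effect, a lower number that less compound is needed), compound 1 (`c1ccc(COc2cc(-c3ccccc3)nc3ccccc23)cc1`) gives > 10 ug/mL, which is a limit of the assay and not a number. Compound 2 (`Oc1ccc2c(O)cc(-c3ccccc3)nc2c1`) gives > 10 ug/mL, which is also a limit. The measured record therefore consists of the limit of > 10 ug/mL in this assay, at which 2 of the 2 values shown sit, and compound 1 has no exact value from which to count a step.

Compound 3 (`CS(=O)(=O)Oc1cc(-c2ccccc2)nc2ccccc12`) has methylsulfonyl in place of benzyl on an oxygen on an aromatic ring. Going by the values given here, no measured pair shows the effect of this change in this assay. Given (the limit of > 10 ug/mL in this assay, at which 2 of the 2 values shown sit), no step beyond the usual scatter is expected, and the change is not expected to favour either direction. The expected step is a step that the limit leaves unreadable from compound 1 to compound 3. Compound 3 is estimated at 12 ug/mL, with an expected range from 5 ug/mL to 30 ug/mL.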

Compound 3, half-maximal effective concentration: 5.6 ug/mL
Compound 3: middle estimate off by 2.1-fold (0.33 log units), on the high side; the measured number falls inside the stated range.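

Going by these compounds alone, compound 3 gives the first exact number in this assay, so the group on this oxygen on an aromatic ring can now be tied to a measurable effect rather than only to a limit. The change from benzyl to methylsulfonyl comes with an at least 1.7-fold lower number from compound 1 to compound 3 (0.25 log units; that floor lies within the scatter), a floor and not a full size, since compound 1 holds only a limit. The size of the step stays unreadable, and the result shows only its direction and smallest possible extent, because so many values sit at the limit: the limit of > 10 ug/mL in this assay, at which 2 of the 3 values shown sit.

The compounds shown leave open whether the number depends on methylsulfonyl itself or would be similar with another group on this oxygen, such as acetyl or plain methyl. They also leave open what a longer chain ending in an amine would give at this place.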